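Chloro in place of bromo: working notes on the series

A few compounds are considered here, and "the series" means these few. Any claim that something is new, unique, unknown or untested is made for them only; others in the source may bear on it.

In a toxicity assay on WI-38 cells (Homo sapiens) for inhibition, read by MTT assay, with a stated time of 48 h (on this read-out higher numbers stand for weaker inhibition and lower numbers for stronger inhibition), compound 1 (`COc1ccc(/C=C2\SC(=O)N(CC(=O)Nc3c(C)n(C)n(-c4ccccc4)c3=O)C2=O)cc1`) gives 52900 nM and compound 2 (`Cc1c(NC(=O)CN2C(=O)S/C(=C\c3ccc(Br)cc3)C2=O)c(=O)n(-c2ccccc2)n1C`) gives 66700 nM. These two values lie within the scatter of each other, so compound 2 cannot be told apart from compound 1 on the numbers available. Compound 3 (`Cc1c(NC(=O)CN2C(=O)S/C(=C\c3ccc(Cl)cc3)C2=O)c(=O)n(-c2ccccc2)n1C`) is still unmeasured. The change to it is chloro in place of bromo on an aromatic carbon, which takes 4-bromophenyl to 4-chlorophenyl: chloro in place of bromo on an aromatic carbon, para to a large group. Within the data shown here, one measured step bears on this, on the same aromatic carbon: bromo in place of methoxy gave a 1.3-fold higher number from compound 1 to compound 2 (0.10 log units; within the scatter). Among the measured compounds shown here, no chloro compound has a value yet, so no step beyond the scatter is expected in this assay. The estimated step is a 1.1-fold lower number from compound 2 to compound 3 (0.05 log units; within the scatter), expected to stay within the scatter. For compound 3 the estimated value is 60000 nM, with an expected range of 35000 nM to 100000 nM.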

Compound 3, half-maximal inhibitory concentration: 54400 nM
Compound 3: the middle estimate sits 1.1-fold (0.04 log units) above what was measured; low and high end bracket the measured number.
By their numbers in this assay, from the lowest: compounds 1, 3 and 2 (each within the scatter of the next).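

In this assay, chloro in place of bromo gives a 1.2-fold lower number from compound 2 to compound 3 (0.09 log units; within the scatter), and chloro in place of methoxy gives a 1.0-fold higher number from compound 1 to compound 3 (0.01 log units; within the scatter). Among these compounds, with three groups now read on the same aromatic carbon, para to a large group, every pair among compound 1, compound 2 and compound 3 lies within the scatter, so none of these groups can be told apart from the others at this position, whereas the earlier compounds offered only a single comparison here. Nothing at hand offers an explanation for this result.

From the compounds shown here alone, whether the same holds for an amine or a carboxylic acid on this carbon remains open. The compounds shown also leave open what a change elsewhere on the shared core would do in this assay.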